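Swapping the nitrophenyl for a pyridine ring

The compounds below may be only part of what the source reports. "The series", "measured", "known", "first", "only" and "open" are said of these compounds alone.

Measured so far, in a functional assay on BJAB cells (Homo sapiens) for antiproliferative activity, with a stated time of 4 days; a lower number here means that less compound is needed, a higher number that more compound is needed for the effect:
Compound 1 `COc1cc(-c2c(C)nn(-c3nc(-c4ccc(Cl)c(Cl)c4)c(SC(C)C)s3)c2C(=O)O)cc(C(F)(F)F)c1` gives 1380 nM.
Compound 2 `Cc1nn(-c2nc(-c3ccc(Cl)c(Cl)c3)c(SC(C)C)s2)c(C(=O)O)c1-c1cccc(F)c1` gives 900 nM.
Compound 3 `Cc1nn(-c2nc(-c3ccc(Cl)c(Cl)c3)c(SC(C)C)s2)c(C(=O)O)c1-c1ccccc1[N+](=O)[O-]` gives 4700 nM.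

Compound 3 stands highest of the three numbers. Its nearest neighbour is compound 1, since a 3.4-fold higher number from compound 1 to compound 3 (0.53 log units; beyond the scatter); further away lies compound 2, since a 5.2-fold higher number from compound 2 to compound 3 (0.72 log units; beyond the scatter). Both steps share one feature: the 2-nitrophenyl group arrives on the same aromatic carbon, and both times the number rises.

Compound 4 `Cc1nn(-c2nc(-c3ccc(Cl)c(Cl)c3)c(SC(C)C)s2)c(C(=O)O)c1-c1cccnc1` is not yet measured. It differs from compound 3 by pyridin-3-yl in place of 2-nitrophenyl on an aromatic carbon. Here the 2-nitrophenyl leaves again, and a pyridin-3-yl enters. Within the data shown here, no measured step introduces a pyridin-3-yl, so the steps from compound 1 and compound 2 to compound 3 are the only guide; read backwards, they suggest that removing the 2-nitrophenyl brings the number down, by a modest step beyond the scatter. Compound 4 is therefore expected at 1500 nM, within 600 nM to 4000 nM, which would mean an estimated 3.1-fold lower number from compound 3 to compound 4 (0.50 log units; beyond the scatter).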

Compound 4, half-maximal effective concentration: 12000 nM
Compound 4: the middle estimate sits 8.0-fold (0.90 log units) below what was measured, outside the stated range (above it).
By their numbers in this assay, from the lowest: compounds 2 and 1 (each within the scatter of the next); then compound 3; then compound 4.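

In this assay, losing the 2-nitrophenyl does not by itself bring the number down at this aromatic carbon: pyridin-3-yl in its place gives a 2.6-fold higher number from compound 3 to compound 4 (0.41 log units; beyond the scatter). The other two rings, both also of carbon only, compare the same way, with a 13-fold higher number from compound 2 to compound 4 (1.12 log units; beyond the scatter) for the 3-fluorophenyl and an 8.7-fold higher number from compound 1 to compound 4 (0.94 log units; beyond the scatter) for the 3-methoxy-5-(trifluoromethyl)phenyl, so among these four compounds the one ring with a hetero atom carries the highest number, and no compound goes against this. Nothing shown here accounts for the rise.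

The compounds shown leave open whether the result depends on where the ring nitrogen sits, as a pyridin-2-yl or pyridin-4-yl would test. They also leave open how a ring with two nitrogens, such as a pyrimidine, or a phenyl bearing an amine would behave at this carbon.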